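Notes on the step to compound 4

The compounds below may be only part of what the source reports. "The series", "measured", "known", "first", "only" and "open" are said of these compounds alone.

In a physicochemical assay for lipophilicity, read by HPLC, at pH 7.5 (on this read-out lower numbers stand for lower lipophilicity and higher numbers for higher lipophilicity), compound 1 (`CC[C@@H](Nc1c(C#N)c(-c2ccc(-c3ccccc3F)cc2)nc2cnccc12)C(N)=O`) gives 2.7 and compound 2 (`CC[C@@H](Nc1c(C#N)c(-c2ccc(-c3cccc(C)c3)cc2)nc2cnccc12)C(N)=O`) gives 3. Compound 3 (`CC[C@@H](Nc1c(C#N)c(-c2ccc(-c3ccncc3C)cc2)nc2cnccc12)C(N)=O`) gives 2, the lowest of the three numbers. Compound 4 (`CC[C@@H](Nc1c(C#N)c(-c2ccc(-c3cccc(Cl)c3F)cc2)nc2cnccc12)C(N)=O`) is still unmeasured. The change is 3-chloro-2-fluorophenyl in place of 3-methylpyridin-4-yl on an aromatic carbon. Two modest measured steps bear on it: a number 0.70 log units lower from compound 1 to compound 3 (beyond the scatter) and a number 1.00 log units lower from compound 2 to compound 3 (beyond the scatter). Read in reverse, both point upward. For the measured compounds named here, no measured compound carries the chlorine, so that part rests on no data. A modest to somewhat larger upward step is expected, estimated as a number 1.20 log units higher from compound 3 to compound 4 (beyond the scatter). Compound 4 is estimated at 3.2, with an expected range of 2.8 to 3.6.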

Compound 4, distribution coefficient: 3.1
Estimate against measurement, compound 4: 0.10 log units above, within the range that was stated.
By their numbers in this assay, from the lowest: compound 3; then compounds 1, 2 and 4 (each within the scatter of the next, the first and the last beyond it).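

In this assay, adding chloro in place of hydrogen on an aromatic carbon gives the series its first measured chlorine step, a number 0.40 log units higher from compound 1 to compound 4 (beyond the scatter). Placing 3-chloro-2-fluorophenyl on this position gives a number 1.10 log units higher from compound 3 to compound 4 (beyond the scatter) against 3-methylpyridin-4-yl, but against 3-methylphenyl it gives a number 0.10 log units higher from compound 2 to compound 4 (within the scatter), so those two aryl groups are not separated. No measurement here gives a cause for these steps.

Still open, as far as these compounds go, is how 3-chlorophenyl, without the fluorine, would read. Also open, from the compounds shown here alone, is where a phenyl ring bearing an amine or a carboxylic acid would fall at this position.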